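A few compounds are considered here, and "the series" means these few. Any claim that something is new, unique, unknown or untested is made for them only; others in the source may bear on it.

Within the data shown here, compound 3 `COc1ccc(C(C)C)c(N2CCC(COc3cccc(C(CC(=O)O)C4CC4)c3)CC2)c1` gives the highest of the three numbers measured so far in a functional assay on cells for agonist activity at Free fatty acid receptor 1 (Homo sapiens), read by FLIPR and calcium flux, with a stated time of 60 min (a lower number here means a smaller maximal response, a higher number a larger maximal response), at 117%. Its nearest neighbour is compound 2 `COc1ccc(CCCC(C)(C)C)c(N2CCC(COc3cccc(C(CC(=O)O)C4CC4)c3)CC2)c1`, which reaches 106% in this assay; the furthest is compound 1 `COc1ccc(F)c(-c2ccc(COc3cccc([C@@H](CC(=O)O)C4CC4)c3)nc2CC(C)(C)C)c1`, which reaches 66% in this assay. Among the measured compounds shown here, the only step that changes a single place is a number 11 percentage points higher from compound 2 to compound 3 (beyond the scatter).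

Compound 4 `COc1ccc(CN(C)CC(C)C)c(N2CCC(COc3cccc(C(CC(=O)O)C4CC4)c3)CC2)c1` has not yet been measured. It differs from compound 3 at one place: (isobutyl(methyl)amino)methyl in place of isopropyl on an aromatic carbon. For the measured compounds named here, the one measured step that bears on this position is a number 11 percentage points higher from compound 2 to compound 3 (beyond the scatter), where a longer chain gave the lower number and the shorter isopropyl gave the higher one. The new group is again larger than isopropyl, so a modest fall beyond the scatter is expected, though nothing measured here shows a nitrogen-containing group at this position, so the expectation is loose. Compound 4 is therefore estimated to reach 100% in this assay, within a range of 75% to 120%, an expected step of a number 17 percentage points lower from compound 3 to compound 4 (beyond the scatter).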

Compound 4, largest response reached (Emax), in percent of the reference or control that the assay uses: 110%
Compound 4: middle estimate off by 10 percentage points, on the low side; the measured number falls inside the stated range.
By their numbers in this assay, from the lowest: compound 1; then compounds 2, 4 and 3 (each within the scatter of the next, the first and the last beyond it).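

With (isobutyl(methyl)amino)methyl in place of isopropyl on this aromatic carbon, para to a methoxy group, this assay shows a number 7 percentage points lower from compound 3 to compound 4 (within the scatter), so a larger group carrying a nitrogen can stand here without a step that clears the scatter. With isobutyl(methyl)amino in place of 3,3-dimethylbutyl, the same assay shows a number 4 percentage points higher from compound 2 to compound 4 (within the scatter), which leaves compound 4 within the scatter of both compound 2 and compound 3, although those two lie beyond the scatter of each other, so these three compounds give no clean order by group size. Nothing available here explains these readings.

The compounds shown leave open how an amide or a carboxylic acid would read on this carbon. They also leave open whether a smaller group, such as methyl or a plain hydrogen, would hold the response.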